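Phenyl for pyridin-3-yl: a single step in the series

The compounds below may be only part of what the source reports. "The series", "measured", "known", "first", "only" and "open" are said of these compounds alone.

Measured so far in a functional assay on HCT-116 cells (Homo sapiens) for inhibition, read by MTT assay, with a stated time of 24 h, tested at 2.5 uM; on this read-out lower numbers stand for less inhibition of growth and higher numbers for more inhibition of growth at the one concentration tested:
compound 1 `CS(=O)(=O)c1ccc(-c2cnc3[nH]cc(-c4nnc(-c5ccc(Cl)cc5)o4)c(=O)c3c2)cc1` gives 2.06%
compound 2 `N#Cc1ccc(-c2cnc3[nH]cc(-c4nnc(-c5ccc(Cl)cc5)o4)c(=O)c3c2)cc1` gives 13.7%
compound 3 `O=c1c(-c2nnc(-c3ccc(Cl)cc3)o2)c[nH]c2ncc(-c3cccnc3)cc12` gives 10.4%

Compound 3 holds the second highest of the three numbers. Its nearest neighbour is compound 2, with a number 3.3 percentage points lower from compound 2 to compound 3 (within the scatter), and its furthest is compound 1, with a number 8.3 percentage points higher from compound 1 to compound 3 (within the scatter); both gaps sit inside the usual scatter, so no order among compounds 2 and 3 can be read from them. For the measured compounds named here, the only step that reaches beyond the scatter is a number 11.6 percentage points higher from compound 1 to compound 2 (beyond the scatter), and even that one is modest.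

Compound 4 `O=c1c(-c2nnc(-c3ccc(Cl)cc3)o2)c[nH]c2ncc(-c3ccccc3)cc12` is not yet measured. It differs from compound 3 in one place: phenyl in place of pyridin-3-yl on an aromatic carbon. The three measured steps all exchange the aryl group at this same position. Two of them, the steps from compound 1 and from compound 2 to compound 3, stayed within the scatter, and the third was modest. On that footing the exchange of pyridin-3-yl for phenyl is expected to move this assay little, with no direction beyond the scatter.

Compound 4 is therefore estimated at 10%, with a range from 2% to 19%. The expected step of a number 0.4 percentage points lower from compound 3 to compound 4 (within the scatter) is within the scatter.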

Compound 4, percent growth inhibition at one concentration: 9.81%
Beside the measured number, compound 4's estimate is 0.2 percentage points above it, and the stated range covers the measured number.
By their numbers in this assay, from the lowest: compounds 1, 4, 3 and 2 (each within the scatter of the next, the first and the last beyond it).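

In this assay the exchange of pyridin-3-yl for phenyl gives a number 0.6 percentage points lower from compound 3 to compound 4 (within the scatter) and so carbon can take the place of the ring nitrogen at this position without a readable change in the number. For the compounds shown here, compound 4 also supplies the plain phenyl reference that the earlier compounds lacked: hydrogen in place of cyano gives a number 3.9 percentage points lower from compound 2 to compound 4 (within the scatter) and hydrogen in place of methylsulfonyl gives a number 7.8 percentage points higher from compound 1 to compound 4 (within the scatter) so neither substituent stands apart from plain phenyl, even though a number 11.6 percentage points higher from compound 1 to compound 2 (beyond the scatter) remains the one gap that passes the scatter. Nothing at hand offers a reason for any of these steps or for their small size.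

The compounds shown leave open whether any group at this position can lift the number clearly above the narrow band seen so far, for example an amine or a carboxylic acid on the phenyl ring, or a morpholine ring in place of the aryl group. They also leave open whether the aryl exchanges would stay this flat at other concentrations or exposure times.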